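Dropping a Chloro from the Core: What Compound 4 May Show

This account rests on a few compounds, and the source may have more. Where it says the series, first, only, none or still open, it means among the compounds named here.

Measured so far:
Compound 1 `CCC1(CCCCN2CCN(c3cccc(Cl)c3)CC2)C(=O)Nc2c(Cl)cc(Cl)cc21` gives 9.46 nM.
Compound 2 `CCC1(CCCCN2CCN(c3ccccc3)CC2)C(=O)Nc2ccccc21` gives 2.07 nM.
Compound 3 `CCC1(CCCCN2CCN(c3ccccc3Cl)CC2)C(=O)Nc2ccccc21` gives 5.11 nM.

These three values come from an assay on CHO cells for displacement of a labelled ligand from 5-hydroxytryptamine receptor 7 (Homo sapiens); a lower number here means a stronger inhibitor, a higher number a weaker inhibitor. Compound 1 has the highest number of the three; its gap to compound 3 lies within the scatter, while its gap to compound 2 lies beyond it.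

One change has been measured directly: hydrogen in place of chloro on an aromatic carbon, which gave a 2.5-fold lower number from compound 3 to compound 2 (0.39 log units; beyond the scatter).

Compound 4 `CCC1(CCCCN2CCN(c3cccc(Cl)c3)CC2)C(=O)Nc2ccc(Cl)cc21` is made from compound 1 by the same kind of change, (hydrogen in place of chloro on an aromatic carbon). The two cores of compound 1 and compound 3 differ, but that difference is not broken down here. The place also differs: in compound 3 the chloro sits ortho to a large group, whereas in compound 1 it sits on a ring that is part of a fused system, ortho to a fused ring and meta to a chloro group. So the change is the same kind, not the same.

Because compound 1 starts at 9.46 nM and the earlier step was a 2.5-fold lower number from compound 3 to compound 2 (0.39 log units; beyond the scatter), a smaller step is expected, a 1.6-fold lower number from compound 1 to compound 4 (0.20 log units; within the scatter). The expected value for compound 4 is 6 nM, between 2 nM and 15 nM.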

Compound 4, inhibition constant: 8.27 nM
Beside the measured number, compound 4's estimate is 1.4-fold (0.14 log units) below it, and the stated range covers the measured number.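

In this assay, putting hydrogen in place of chloro on an aromatic carbon, ortho to a fused ring, gives a 1.1-fold lower number from compound 1 to compound 4 (0.06 log units; within the scatter), so at this place the chloro can go without a measurable shift in the number. The earlier step of the same kind, a 2.5-fold lower number from compound 3 to compound 2 (0.39 log units; beyond the scatter), does lie beyond the scatter on its own, yet the two steps cannot be told apart: the same change on two cores in this assay, a 2.5-fold lower number (0.39 log units; beyond the scatter) from compound 3 to compound 2 and a 1.1-fold lower number (0.06 log units; within the scatter) from compound 1 to compound 4, 2.2-fold (0.33 log units) apart, within the scatter of two such steps. Going by these compounds alone, this shows that the two results are compatible with a single modest step, but it does not show that the change carries over from one core to another, since each core offers only one pair and the chloro sits in a different place in each.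

Going by these compounds, whether a fluoro or a methoxy group at this same place would leave the number just as unmoved remains open. Within the data shown here, also open is what happens when the other chloro on this ring, the one that compound 4 keeps, is replaced by hydrogen.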